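The source may hold more compounds than are shown below. What is called first, only, known or untested is meant among the compounds shown, and "the series" means these compounds.

The measured compounds in an ADME assay on microsomes from liver (Mus musculus) for metabolic stability, read by LC-MS, using NADPH, with a stated time of 60 min, tested at 1 uM, in the presence of a further agent that is not named here; a higher number here means faster removal of the compound, a lower number slower removal:
compound 1, `Cc1ccc2nc(-c3ccccn3)c(Nc3ccc4c(c3)OCCO4)n2c1`, gives 411 uL/min
compound 2, `CN(c1ccc(F)cc1)c1c(-c2ccccn2)nc2ccccn12`, gives > 1000 uL/min, which is a limit of the assay and not a number
compound 3, `COc1ccn2c(Nc3ccccc3F)c(-c3ccccn3)nc2c1`, gives 133 uL/min

Compound 3 holds the lowest of the two numbers in this assay; the nearest is compound 1, whose value sits beyond the scatter above it. Compound 2 sits at the limit of > 1000 uL/min in this assay, at which 1 of the 3 values shown sits. Compound 4, `COc1ccn2c(Nc3cc(F)cc(F)c3)c(-c3ccccn3)nc2c1`, has not yet been measured in this assay. It differs from compound 3 in one place: 3,5-difluorophenyl in place of 2-fluorophenyl on a nitrogen on an aromatic ring. Among the three measured compounds no two differ in one place only, so the data give no measured step of this kind to lean on. The account therefore expects the step of a 1.1-fold lower number from compound 3 to compound 4 (0.03 log units; within the scatter) to stay within the usual scatter, with no firm direction either way. On that basis compound 4 is estimated to show about 125 uL/min in this assay. Compound 4 is expected to fall somewhere between 55 uL/min and 270 uL/min, and the measurement will tell whether the second fluorine on the aromatic ring moves the number at all.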

Compound 4, intrinsic clearance in a liver preparation (reported as CLH), per the amount of preparation that the assay uses: 62 uL/min
The estimate for compound 4 lay 2.0-fold (0.30 log units) above the measured number; low and high end bracket the measured number.
By their numbers in this assay, from the lowest: compound 4; then compound 3; then compound 1. At a limit, above all of these: compound 2.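

Among these compounds, replacing 2-fluorophenyl with 3,5-difluorophenyl on the nitrogen gives, in this assay, a 2.1-fold lower number from compound 3 to compound 4 (0.33 log units; beyond the scatter), which is the first step between two measured compounds that differ in one place. It shows that the number in this assay responds to a change at this position, even though the step is modest, and that the group entering here, with its second fluorine and one more heavy atom, goes with a lower number rather than a higher one. Nothing measured for these compounds bears on why the number moves with this change.

This single step cannot separate the effect of adding a second fluorine from that of moving the fluorine away from where it sits in 2-fluorophenyl, and it leaves open how a ring carrying a single fluorine in another place, or a chlorine, a nitrile or a methoxy group in place of fluorine, would read at this position. As far as these compounds go, it is also open whether 3,5-difluorophenyl would bring a similar step on the core of compound 1 or on other substituted versions of the shared core.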